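Two Methyls on the Phenyl Ring: Expected Cytotoxicity

This account rests on a few compounds, and the source may have more. Where it says the series, first, only, none or still open, it means among the compounds named here.

Compound 1 `CC1(C)CCC[C@]2(C)[C@@H](CC[C@@](C)(O)/C=C/c3ccccc3)[C@](C)(O)CC[C@@H]12` was tested in a functional assay on A549 cells (Homo sapiens) for cytotoxicity, read by MTT assay, with a stated time of 48 h (a lower number here means a stronger inhibitor, a higher number a weaker inhibitor), where compound 1 gives 3150 nM. Its only measured companion, compound 2 `CC1(C)CCC[C@]2(C)[C@@H](CC[C@@](C)(O)/C=C/c3cccc([N+](=O)[O-])c3)[C@](C)(O)CC[C@@H]12`, carries a nitro group on the aromatic ring, and in this assay compound 2 gives 3400 nM. The step of a 1.1-fold higher number from compound 1 to compound 2 (0.03 log units; within the scatter) shows that this change made no difference worth noting. Of the two measured compounds, compound 1 has the lowest number, with compound 2 essentially level with it.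

Compound 3 `Cc1cccc(/C=C/[C@](C)(O)CC[C@@H]2[C@@]3(C)CCCC(C)(C)[C@@H]3CC[C@@]2(C)O)c1C` has not yet been measured. It differs from compound 1 in one place: 2,3-dimethylphenyl in place of phenyl on a double-bonded chain carbon bound to a double-bonded chain carbon. Going by the values given here, the single measured step, from compound 1 to compound 2, altered the same aromatic ring and left the number within the scatter, so it gives no sign that decorating this ring moves the result. The step of a 1.1-fold lower number from compound 1 to compound 3 (0.02 log units; within the scatter) is expected to stay within the scatter. For compound 3 the estimate in this assay is 3000 nM, with a range from 1500 nM to 6500 nM.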

Compound 3, half-maximal inhibitory concentration: 3800 nM
Compound 3: the middle estimate sits 1.3-fold (0.10 log units) below what was measured; low and high end bracket the measured number.
By their numbers in this assay, from the lowest: compounds 1, 2 and 3 (each within the scatter of the next).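

Placing two methyl groups on the ring gives a 1.2-fold higher number from compound 1 to compound 3 (0.08 log units; within the scatter) in this assay and leaves the number effectively unchanged. Setting 2,3-dimethylphenyl in place of 3-nitrophenyl gives a 1.1-fold higher number from compound 2 to compound 3 (0.05 log units; within the scatter) and is also no real change, so phenyl, 3-nitrophenyl and 2,3-dimethylphenyl all read alike on this double-bonded chain carbon. Nothing measured here explains why the number holds steady across these three groups.

On these data alone, all three groups are aromatic rings of carbon only, and the ring substituents cover only nitro and methyl, so it remains open whether an amine or a carboxylic acid on the ring would read the same. As far as these compounds go, it also remains open whether a change away from this ring, in the shared core or the chain, would move the number at all.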